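Longer alkyl chains and MCF7 antiproliferative potency

This account rests on a few compounds, and the source may have more. Where it says the series, first, only, none or still open, it means among the compounds named here.

The measured compounds:
- compound 1, `CCCCCCCCn1cc(COC[C@@H]2OC[C@H](N)[C@@H]2O)nn1`: 28100 nM
- compound 2, `CCCCCCCCCCn1cc(COC[C@@H]2OC[C@H](N)[C@@H]2O)nn1`: 9640 nM
- compound 3, `CCCCCCCCCCCCCCn1cc(COC[C@@H]2OC[C@H](N)[C@@H]2O)nn1`: 1850 nM

Three compounds share one core and differ only in the length of the saturated chain attached to the aromatic nitrogen. In a functional assay on MCF7 cells (Homo sapiens) for antiproliferative activity, read by MTT assay, with a stated time of 48 h (on this read-out lower numbers stand for stronger inhibition and higher numbers for weaker inhibition), compound 1 gives 28100 nM, compound 2 gives 9640 nM, and compound 3 gives 1850 nM. The change from compound 1 to compound 2 is ethyl in place of hydrogen on a saturated chain carbon, eight bonds along the chain from an aromatic nitrogen, and it brought a 2.9-fold lower number from compound 1 to compound 2 (0.46 log units; beyond the scatter). The longer extension from compound 1 to compound 3 is hexyl in place of hydrogen on a saturated chain carbon, eight bonds along the chain from an aromatic nitrogen, and it brought a 15-fold lower number from compound 1 to compound 3 (1.18 log units; beyond the scatter). Between compound 2 and compound 3 the step was a 5.2-fold lower number from compound 2 to compound 3 (0.72 log units; beyond the scatter). Within these three compounds, every lengthening of the chain has gone with a lower number, and compound 3 stands lowest.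

Compound 4, `CCCCCCCCCCCCCCCCn1cc(COC[C@@H]2OC[C@H](N)[C@@H]2O)nn1`, has not yet been measured in this assay. It differs from compound 3 by ethyl in place of hydrogen on a saturated chain carbon, ten or more bonds along the chain from an aromatic nitrogen. Going by the values given here, this is the same kind of change as the one from compound 1 to compound 2, but it sits further out along the chain, as the two difference descriptions show. Beside the earlier step, a 2.9-fold lower number from compound 1 to compound 2 (0.46 log units; beyond the scatter), a step of similar or somewhat smaller size is expected from compound 3 to compound 4, namely a 1.9-fold lower number from compound 3 to compound 4 (0.27 log units; within the scatter), because a 5.2-fold lower number from compound 2 to compound 3 (0.72 log units; beyond the scatter) suggests that each further pair of chain carbons has continued to lower the number, though only three points support that trend. Compound 4 is therefore estimated to give 1000 nM in this assay, with a plausible range from 400 nM to 4000 nM.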

Compound 4, half-maximal inhibitory concentration: 3300 nM
Estimate against measurement, compound 4: 3.3-fold (0.52 log units) below, and the stated range covers the measured number.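

In this assay, an ethyl extension that lowered the number on the shorter chain did not do the same on the longer one, where the new step is a 1.8-fold higher number from compound 3 to compound 4 (0.25 log units; within the scatter), so the two results differ: the same change on two cores in this assay, a 2.9-fold lower number (0.46 log units; beyond the scatter) from compound 1 to compound 2 and a 1.8-fold higher number (0.25 log units; within the scatter) from compound 3 to compound 4, 5.2-fold (0.72 log units) apart, beyond the scatter of two such steps

The hexyl extension also carries over only in part, since a 2.9-fold lower number from compound 2 to compound 4 (0.47 log units; beyond the scatter) is a smaller step than the one seen earlier: the same change on two cores in this assay, a 15-fold lower number (1.18 log units; beyond the scatter) from compound 1 to compound 3 and a 2.9-fold lower number (0.47 log units; beyond the scatter) from compound 2 to compound 4, 5.2-fold (0.72 log units) apart, beyond the scatter of two such steps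

Compound 4 still keeps a clear gain over the shortest chain, with an 8.5-fold lower number from compound 1 to compound 4 (0.93 log units; beyond the scatter), so the size of a chain extension in this series depends on the chain it starts from, and the gain from one step cannot simply be copied to the next; these results do not show why the steps differ, and compound 3 and compound 4 cannot be told apart on this read-out, so they do not show whether the trend levels off or turns back.

The compounds shown leave open what a still longer chain would give, which is what could separate a plateau from a true reversal. They also leave open whether a chain carrying a carboxylic acid or a hydroxyl group would behave like these plain alkyl chains.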